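Nitro to amino: compound 2 to compound 3

The compounds below may be only part of what the source reports. "The series", "measured", "known", "first", "only" and "open" are said of these compounds alone.

Measured in a functional assay on K562 cells (Homo sapiens) for cytotoxicity, read by trypan blue exclusion, with a stated time of 96 h; on this read-out lower numbers stand for stronger inhibition and higher numbers for weaker inhibition:
- compound 1 `COc1cc(OC)c(/C=C/S(=O)(=O)Cc2ccc(OC)c(N)c2)c(OC)c1`: 2.5 nM
- compound 2 `COc1cc(OC)c(/C=C/SCc2ccc(OC)c([N+](=O)[O-])c2)c(OC)c1`: 5000 nM

Compound 2, at 5000 nM, holds the higher of the two numbers, and the number of compound 1 lies beyond the scatter from it. Compound 3 `COc1cc(OC)c(/C=C/SCc2ccc(OC)c(N)c2)c(OC)c1` has amino in place of nitro on an aromatic carbon, ortho to a methoxy group (amino in place of nitro on an aromatic carbon). In this assay a move to a lower number, beyond the scatter, is expected, with an estimated step of a 25-fold lower number from compound 2 to compound 3 (1.40 log units; beyond the scatter). This expectation rests on compound 1 at 2.5 nM, which also carries amino. For compound 3 the estimate is 200 nM, with an expected range of 15 nM to 3000 nM.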

Compound 3, half-maximal inhibitory concentration: 30 nM
Compound 3: middle estimate off by 6.7-fold (0.82 log units), on the high side, within the range that was stated.
By their numbers in this assay, from the lowest: compound 1; then compound 3; then compound 2.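

In this assay, among the compounds shown here, amino in place of nitro on an aromatic carbon, ortho to a methoxy group, gives a 170-fold lower number from compound 2 to compound 3 (2.22 log units; beyond the scatter) as the first direct single-place reading at this position. The change is large, but it rests on this one pair. Nothing available bears on the origin of the step.

Open: how a hydroxyl, an acetamide or a dimethylamino group would read at this position in this assay. Also open, going by these compounds, is whether the step holds with the sulfonyl link of compound 1 in place of the sulfur link of compound 3.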